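Extending the hydroxylated ester side chain of compound 3

The source may report more compounds than this note shows. Statements on the series, on what has been measured and on what is new or still open speak of the compounds shown alone.

Compound 3 `CC[C@](C)(O)CC(=O)O[C@H](CC=C(C)C)C1=CC(=O)c2c(O)ccc(O)c2C1=O` carries the lowest of the two numbers seen here in a functional assay on HeLa cells (Homo sapiens) for cytotoxicity, read by MTT assay; on this read-out lower numbers stand for stronger inhibition and higher numbers for weaker inhibition; compound 3 gives 30200 nM. Compound 2 `CCCC(O)CC(=O)O[C@H](CC=C(C)C)C1=CC(=O)c2c(O)ccc(O)c2C1=O` gives 59300 nM, and the step is a 2.0-fold lower number from compound 2 to compound 3 (0.29 log units; within the scatter). For compound 1 `CC(C)=CC[C@@H](OC(=O)c1ccoc1)C1=CC(=O)c2c(O)ccc(O)c2C1=O` only a limit is known, > 100000 nM. Compound 4 `CCC(O)(CC)CC(=O)O[C@H](CC=C(C)C)C1=CC(=O)c2c(O)ccc(O)c2C1=O` differs from compound 3 by 1-ethyl-1-hydroxypropyl in place of 1-hydroxy-1-methylpropyl on a saturated chain carbon bound to a carbonyl carbon. Among the measured compounds shown here, the one measured step at the same place, a 2.0-fold lower number from compound 2 to compound 3 (0.29 log units; within the scatter), stayed within the scatter, while both changes away from furan-3-yl, an at least 1.6-fold lower number from compound 1 to compound 2 (0.22 log units; that floor lies within the scatter) and an at least 3.3-fold lower number from compound 1 to compound 3 (0.51 log units; beyond the scatter), rest on the limit (the limit of > 100000 nM in this assay, at which 1 of the 3 values shown sits). Compound 4 is therefore expected to show a step of a 1.2-fold lower number from compound 3 to compound 4 (0.08 log units; within the scatter). The estimate for compound 4 is 25000 nM, ranging from 10000 nM to 70000 nM.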

Compound 4, half-maximal inhibitory concentration: 52000 nM
For compound 4 the middle estimate is 2.1-fold (0.32 log units) below the measured one; the measured number falls inside the stated range.
By their numbers in this assay, from the lowest: compounds 3, 4 and 2 (each within the scatter of the next). At a limit, above all of these: compound 1.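

In this assay the change from 1-hydroxy-1-methylpropyl to 1-ethyl-1-hydroxypropyl gives a 1.7-fold higher number from compound 3 to compound 4 (0.24 log units; within the scatter) and the change from 1-hydroxybutyl to 1-ethyl-1-hydroxypropyl gives a 1.1-fold lower number from compound 2 to compound 4 (0.06 log units; within the scatter), so these three hydroxylated chains do not separate at this place. The change from furan-3-yl to 2-ethyl-2-hydroxybutyl on a carbonyl carbon gives an at least 1.9-fold lower number from compound 1 to compound 4 (0.28 log units; that floor lies within the scatter) and rests on a limit: the limit of > 100000 nM in this assay, at which 1 of the 4 values shown sits. The compounds shown leave open whether a longer chain, an amine or a carboxylic acid at this place would move the number beyond the scatter. They also leave open what a chain without the hydroxyl would give.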